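Benzyl at the aromatic nitrogen: expectation for compound 4

The source may hold more compounds than are shown below. What is called first, only, known or untested is meant among the compounds shown, and "the series" means these compounds.

Of the compounds shown here, three have been measured in a functional assay on HepG2 cells (Homo sapiens) for inhibition, read by MTT assay, with a stated time of 72 h; on this read-out lower numbers stand for stronger inhibition and higher numbers for weaker inhibition. Compound 1 `Cc1ccc(-n2cc(CNC(=O)c3cccc4c3cnn4C(C)C)nn2)cc1` reaches only a limit of the assay in this assay, > 40000 nM. Compound 2 `Cc1cccc(-n2cc(CNC(=O)c3cccc4c3cnn4C(C)C)nn2)c1` likewise gives only a limit, > 40000 nM. Compound 3 `COc1ccc(-n2cc(CNC(=O)c3cccc4c3cnn4C(C)C)nn2)cc1` also stops at a limit, > 40000 nM, so no number stands for it, only a bound. Because every value sits at the limit of > 40000 nM in this assay, at which 3 of the 3 values shown sit, the steps between these compounds cannot be sized: a step that the two limits leave unreadable from compound 1 to compound 2, a step that the two limits leave unreadable from compound 1 to compound 3 and a step that the two limits leave unreadable from compound 2 to compound 3 are all unreadable.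

Compound 4 `CC(C)n1ncc2c(C(=O)NCc3cn(Cc4ccccc4)nn3)cccc21` has not yet been measured. It differs from compound 3 in one place: benzyl in place of 4-methoxyphenyl on an aromatic nitrogen. Among the compounds with values here, none of the measured steps can be read, so none gives a direction for this change; they show only that 4-methylphenyl, 3-methylphenyl and 4-methoxyphenyl at this position all leave inhibition beyond the limit. Within the data shown here, the benzyl group is untested here and no step of readable size bears on it. The expectation for compound 4 is therefore that this assay again reports a limit, with an estimate of 40000 nM and a range from 15000 nM to 100000 nM. The step this estimate implies is expected to be a number no higher from compound 3 to compound 4 (the limit leaves the size open).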

Compound 4, half-maximal inhibitory concentration: 13700 nM
For compound 4 the middle estimate is 2.9-fold (0.47 log units) above the measured one; measured number below the stated range.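

In this assay the group on the aromatic nitrogen now shows a readable effect on inhibition: benzyl in place of 4-methoxyphenyl gives an at least 2.9-fold lower number from compound 3 to compound 4 (0.46 log units; beyond the scatter). The same holds for the other two groups, with benzyl in place of 3-methylphenyl giving an at least 2.9-fold lower number from compound 2 to compound 4 (0.46 log units; beyond the scatter) and benzyl in place of 4-methylphenyl giving an at least 2.9-fold lower number from compound 1 to compound 4 (0.46 log units; beyond the scatter). Compound 4 is the only compound shown with a number, so each of these steps gives only a minimum size: the limit of > 40000 nM in this assay, at which 3 of the 4 values shown sit.

The steps among compound 1, compound 2 and compound 3 cannot be read, so nothing separates 4-methylphenyl, 3-methylphenyl and 4-methoxyphenyl from one another, and a single benzyl compound cannot show how far this change can be taken. Also open, going by these compounds, is how inhibition responds on this nitrogen to a phenethyl group, to a 4-methoxybenzyl group, which would carry the methoxy of compound 3 on the benzyl ring, or to a plain butyl chain with no ring at all.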